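Replacing a difluorophenyl with a pyrimidinyl pyrrolidinone

The source may report more compounds than this note shows. Statements on the series, on what has been measured and on what is new or still open speak of the compounds shown alone.

The account begins with compound 1, `O=C(Nc1cc(F)c(F)c(F)c1)N1Cc2c(-c3ccc(F)cc3F)cnn2CC1C1CC1`, which was examined in a toxicity assay on HepG2 2.2.15 cells (Homo sapiens) for cytotoxicity, read by CellTiter-Glo; on this read-out lower numbers stand for higher toxicity in this test and higher numbers for lower toxicity in this test. In this assay compound 1 gives 32100 nM, the lowest of the two numbers recorded so far. For the measured compounds named here, its only companion is compound 2, `O=C1CC(Oc2ncc(F)cn2)CN1c1cnn2c1CN(C(=O)Nc1cc(F)c(F)c(F)c1)C(C1CC1)C2`, which in this assay gives 96200 nM; the gap between these two values lies beyond the usual scatter of repeated measurements, so compound 1 is the more toxic of the pair in this test.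

The step under consideration leads from compound 1 to compound 3, `O=C1CC(c2ncccn2)CN1c1cnn2c1CN(C(=O)Nc1cc(F)c(F)c(F)c1)C(C1CC1)C2`. The change is 2-oxo-4-(pyrimidin-2-yl)pyrrolidin-1-yl in place of 2,4-difluorophenyl on an aromatic carbon. Going by the values given here, no measured pair of neighbours shows the effect of this particular exchange, so the expectation rests on the two values given. Because compound 2 gives 96200 nM, a larger and more polar substituent at this position is expected to push the number upward, toward lower toxicity. The step from compound 1 to compound 3 is therefore estimated as a 2.3-fold higher number from compound 1 to compound 3 (0.37 log units; beyond the scatter). Compound 3 is expected to give about 75000 nM, within a range from 32000 nM to 180000 nM.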

Compound 3, half-maximal cytotoxic concentration: > 200000 nM
Compound 3 was reported as a limit (the forecaster's own chance of this, stated with the estimate: 25%); middle value at least 2.6-fold (0.42 log units) from the limit.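

Compound 3 in this assay is reported only as a limit of the assay and not as a number: the limit of > 200000 nM in this assay, at which 1 of the 3 values shown sits. For the compounds shown here, putting 2-oxo-4-(pyrimidin-2-yl)pyrrolidin-1-yl in place of 2,4-difluorophenyl on the aromatic carbon gives an at least 6.2-fold higher number from compound 1 to compound 3 (0.79 log units; beyond the scatter), which is the first single-place change at this position and shows that it moves the read-out towards lower toxicity in this test. Pyrimidin-2-yl in place of (5-fluoropyrimidin-2-yl)oxy on a saturated ring carbon gives an at least 2.0-fold higher number from compound 2 to compound 3 (0.31 log units; beyond the scatter), so the group carried on that saturated ring also changes the read-out, and the exchange on the aromatic carbon is not the only thing that matters.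

Going by these compounds alone, with compound 3 at a limit, the true size of both steps stays open, and the single exchange on the aromatic carbon does not separate what the five-membered ring contributes from what the pyrimidin-2-yl contributes. Going by these compounds, it also stays open whether an amine, a carboxylic acid or a plain methyl on the same saturated ring carbon would keep the read-out this high.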